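This account rests on a few compounds, and the source may have more. Where it says the series, first, only, none or still open, it means among the compounds named here.

Of the compounds shown here, two have been measured in an assay on HEK293 cells for inhibition of potassium channel subfamily T member 1 (Homo sapiens), read by thallium flux; on this read-out higher numbers stand for weaker inhibition and lower numbers for stronger inhibition. Compound 1 `COc1ccc(Cl)cc1NC(=O)N1CCCN(S(=O)(=O)N2CCC(C)CC2)CC1` gives 6200 nM. Compound 2 `CC1CCN(S(=O)(=O)N2CCN(CC(=O)Nc3cc(Cl)ccc3OC(C)C)CC2)CC1` gives 5100 nM; the two values lie within the scatter of each other, so neither compound stands apart from the other on these numbers. Compound 3 `CC1CCN(S(=O)(=O)N2CCN(CC(=O)Nc3cc(Cl)ccc3OCC3CC3)CC2)CC1` has not yet been measured. It differs from compound 2 in one place: cyclopropylmethyl in place of isopropyl on an oxygen on an aromatic ring. Among the compounds with values here, no measured pair in the set carries this change, so nothing in the data tells its size or direction. With one substituent on the aromatic oxygen exchanged for another of similar kind, the step expected in this assay, a 1.1-fold lower number from compound 2 to compound 3 (0.05 log units; within the scatter), is small, without a clear direction, and not beyond the scatter. Compound 3 is accordingly estimated at 4500 nM in this assay, with a range from 1800 nM to 12000 nM.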

Compound 3, half-maximal inhibitory concentration: 7500 nM
Beside the measured number, compound 3's estimate is 1.7-fold (0.22 log units) below it; the measured number falls inside the stated range.
By their numbers in this assay, from the lowest: compounds 2, 1 and 3 (each within the scatter of the next).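

In this assay, within the data shown here, cyclopropylmethyl in place of isopropyl on an oxygen on an aromatic ring gives a 1.5-fold higher number from compound 2 to compound 3 (0.17 log units; within the scatter), the first step that can be read at this position. This position therefore carries either group, the second with one more carbon and a three-membered ring, without a step beyond the scatter, and this exchange sets no order between the two groups. Nothing at hand bears on the reason for this result.

Still open, as far as these compounds go, is how a group of another kind reads on this oxygen, such as a longer alkyl chain, an amine or a carboxylic acid, and whether any of these moves the number beyond the scatter. Equally open, from the compounds shown here alone, is whether cyclopropylmethyl reads the same way on the core of compound 1.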